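Trimming a Trimethoxy Cap on a Hydroxamate Deacetylase Inhibitor

The source may hold more compounds than are shown below. What is called first, only, known or untested is meant among the compounds shown, and "the series" means these compounds.

Of the compounds shown here, three sharing one core have been tested in an assay on isolated protein for inhibition of protein deacetylase HDAC6 (Homo sapiens); a lower number here means a stronger inhibitor, a higher number a weaker inhibitor. Compound 1 `COc1cc(C(=O)NOCCCCCC(=O)NO)cc(OC)c1OC` gives 60 nM, the lowest of the three numbers. Compound 3 `O=C(CCCCCONC(=O)c1cc(F)cc(F)c1)NO` gives 100 nM, which sits within the scatter of compound 1. Compound 2 `CC(C)(C)c1cc(C(=O)NOCCCCCC(=O)NO)cc(C(C)(C)C)c1` gives 2150 nM, far beyond the scatter. The next compound, compound 4 `COc1cc(OC)cc(C(=O)NOCCCCCC(=O)NO)c1`, differs from compound 1 in one place: hydrogen in place of methoxy on an aromatic carbon, a hydrogen in place of methoxy on an aromatic carbon. Among the compounds with values here, no measured pair shows such a change, so the expected step rests on the closeness of compound 1 and compound 3 with their different caps. The step from compound 1 to compound 4 in this assay is expected to be small, a 1.5-fold higher number from compound 1 to compound 4 (0.18 log units; within the scatter), likely within the scatter. Compound 4 is therefore estimated at 90 nM, with a range from 40 nM to 250 nM.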

Compound 4, inhibition constant: 30 nM
Estimate against measurement, compound 4: 3.0-fold (0.48 log units) above, and the stated range ends above it.
By their numbers in this assay, from the lowest: compounds 4, 1 and 3 (each within the scatter of the next, the first and the last beyond it); then compound 2.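

The methoxy group ortho to two methoxy groups and para to a large group can be replaced by hydrogen without a measurable loss in this assay: the result is a 2.0-fold lower number from compound 1 to compound 4 (0.30 log units; within the scatter), so the full trimethoxy pattern of compound 1 is not needed to keep binding in this range. This single step cannot separate a real gain from scatter, and no separate measurement here explains it.

As far as these compounds go, how an amine or a hydroxyl group would behave at this same position remains open. So does the effect of replacing either remaining methoxy group of compound 4 with hydrogen.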